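Moving the Amino Group of Compound 2

A few compounds are considered here, and "the series" means these few. Any claim that something is new, unique, unknown or untested is made for them only; others in the source may bear on it.

Compound 1 `C/C(=C\C(=O)N1CCC(Cn2c(C)nc3cnccc32)CC1)c1ccc(N)cc1`: 60 nM
Compound 2 `Cc1nc2cnccc2n1CC1CCN(C(=O)/C=C(/c2ccccc2)c2ccc(N)cc2)CC1`: 8 nM
Compound 3 `Cc1nc2cnccc2n1CC1CCN(C(=O)/C=C(\c2ccccc2)c2ccc(N)cc2)CC1`: 5 nM

In a functional assay on the whole organism with Oryctolagus cuniculus as the target (on this read-out higher numbers stand for weaker inhibition and lower numbers for stronger inhibition), compound 2 gives 8 nM, within the scatter of compound 3 and clearly lower than compound 1. Compound 4 `Cc1nc2cnccc2n1CC1CCN(C(=O)/C=C(/c2ccccc2)c2cccc(N)c2)CC1` carries 3-aminophenyl in place of 4-aminophenyl on a double-bonded chain carbon bound to an aromatic carbon and a double-bonded chain carbon. Neither measured step moves the amino group, so both bear on this change only indirectly. Reversing the double-bond configuration gave a 1.6-fold lower number from compound 2 to compound 3 (0.20 log units; within the scatter), while phenyl in place of methyl gave a 12-fold lower number from compound 1 to compound 3 (1.08 log units; beyond the scatter). The aryl-bearing scaffold of compound 2 is kept, so only a small shift is expected in this assay, leaning towards a higher number and not clearly beyond the scatter. The expected step is a 1.5-fold higher number from compound 2 to compound 4 (0.18 log units; within the scatter). For compound 4 the estimated value is 12 nM, with an expected range from 3 nM to 50 nM.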

Compound 4, half-maximal inhibitory concentration: 190 nM
Estimate against measurement, compound 4: 16-fold (1.20 log units) below; the measured number lies above the stated range.
By their numbers in this assay, from the lowest: compounds 3 and 2 (each within the scatter of the next); then compound 1; then compound 4.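

In this assay, 3-aminophenyl in place of 4-aminophenyl gave a 24-fold higher number from compound 2 to compound 4 (1.38 log units; beyond the scatter), although the entering and leaving groups have the same counted atoms and differ only in how they are joined. The placement of the amino group on this aryl group therefore counts for far more here than reversing the double bond, which gave a 1.6-fold lower number from compound 2 to compound 3 (0.20 log units; within the scatter). Nothing available explains the size of this step.

The compounds shown leave open whether the same loss holds for the opposite double-bond configuration of compound 3. They also leave open whether a hydroxyl or a methylamino group would be tolerated in place of the amine.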